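Working notes: amine variation on the shared core

The compounds below may be only part of what the source reports. "The series", "measured", "known", "first", "only" and "open" are said of these compounds alone.

Measured so far:
compound 1 `CC(=O)NC1CCN(c2nc3c(c(Nc4ccc(C(F)(F)F)cc4)n2)CCN(c2ncccc2C(F)(F)F)CC3)C1`: 150 nM
compound 2 `FC(F)(F)c1ccc(Nc2nc(N3CCN(C4CCC4)CC3)nc3c2CCN(c2ncccc2C(F)(F)F)CC3)cc1`: 24 nM
compound 3 `CCC(CC)N1CCN(c2nc3c(c(Nc4ccc(C(F)(F)F)cc4)n2)CCN(c2ncccc2C(F)(F)F)CC3)CC1`: 41 nM

In a functional assay on HEK293 cells for antagonist activity at transient receptor potential cation channel subfamily V member 1 (Homo sapiens), read by FLIPR and calcium flux (a lower number here means a stronger inhibitor, a higher number a weaker inhibitor), compound 1 gives the highest of the three numbers; compound 3 is nearest and compound 2 furthest, both beyond the scatter. Compound 4 `CN(c1nc2c(c(Nc3ccc(C(F)(F)F)cc3)n1)CCN(c1ncccc1C(F)(F)F)CC2)C1CCCNC1` is not yet measured. It differs from compound 1 in one place: methyl(piperidin-3-yl)amino in place of 3-acetamidopyrrolidin-1-yl on an aromatic carbon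

Going by the values given here, two measured steps bear on this change, both swapping the same 3-acetamidopyrrolidin-1-yl for another amine at the same position: a 6.3-fold lower number from compound 1 to compound 2 (0.80 log units; beyond the scatter) and a 3.7-fold lower number from compound 1 to compound 3 (0.56 log units; beyond the scatter). Compounds 2 and 3 lie within the scatter of each other (a 1.7-fold higher number from compound 2 to compound 3 (0.23 log units; within the scatter)), so the size of the amine mattered little there. A modest step toward a lower number is therefore expected for compound 4, though its amine is of a different pattern and the step could fall short. The estimate for compound 4 is 60 nM (range 20 nM to 180 nM), which means an expected 2.5-fold lower number from compound 1 to compound 4 (0.40 log units; beyond the scatter).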

Compound 4, half-maximal inhibitory concentration: 3600 nM
For compound 4 the middle estimate is 60-fold (1.78 log units) below the measured one; measured number outside the range, above it.
By their numbers in this assay, from the lowest: compounds 2 and 3 (each within the scatter of the next); then compound 1; then compound 4.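

In this assay, the amine at this aromatic carbon can also raise the number sharply: methyl(piperidin-3-yl)amino in place of 3-acetamidopyrrolidin-1-yl gives a 24-fold higher number from compound 1 to compound 4 (1.38 log units; beyond the scatter), whereas the two earlier swaps at this position both lowered it. The same group gives larger rises against the piperazines, with an 88-fold higher number from compound 3 to compound 4 (1.94 log units; beyond the scatter) and a 150-fold higher number from compound 2 to compound 4 (2.18 log units; beyond the scatter). Nothing measured here explains this rise.

Still open, on these data alone, is whether the rise goes with the methyl on the linking nitrogen or with the unsubstituted piperidine nitrogen. An acetyl group on that piperidine nitrogen would help separate the two.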